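A Fluoro Step Repeated on a Second Core

The source may hold more compounds than are shown below. What is called first, only, known or untested is meant among the compounds shown, and "the series" means these compounds.

Compound 2 `COc1cc2c(Oc3ccc(NC(=O)c4cc(-c5ccccc5)ccn4)cc3F)ccnc2cc1OCCCN1CCCCC1` gives 790 nM in a functional assay on U-87MG ATCC cells (Homo sapiens) for cytotoxicity, read by MTT assay, with a stated time of 72 h; a higher number here means a weaker inhibitor, a lower number a stronger inhibitor. Compound 1 `COc1cc2c(Oc3ccc(NC(=O)c4cc(-c5ccc(F)cc5)ccn4)cc3F)ccnc2cc1OCCCN1CCCCC1` differs from it by fluoro in place of hydrogen on an aromatic carbon and in this assay compound 1 gives 12500 nM, which is a 16-fold higher number from compound 2 to compound 1 (1.20 log units; beyond the scatter). Compound 3 `COc1cc2c(Oc3ccc(NC(=O)c4nccc(-c5ccc(F)cc5)n4)cc3F)ccnc2cc1OCCCN1CCN(C)CC1` carries a core whose difference from compound 2 is not broken down here, and in this assay compound 3 gives 910 nM. Compound 4 `COc1cc2c(Oc3ccc(NC(=O)c4nccc(-c5ccc(F)cc5F)n4)cc3F)ccnc2cc1OCCCN1CCN(C)CC1` differs from compound 3 by fluoro in place of hydrogen on an aromatic carbon. This is the same kind of change as that from compound 2 to compound 1, but not the same: there the entering fluoro sat para to a large group, here it sits ortho to a large group and meta to a fluoro group. Because the earlier change gave a 16-fold higher number from compound 2 to compound 1 (1.20 log units; beyond the scatter), a weakening is expected for compound 4, but with the place not the same a smaller step is expected, estimated at a 2.0-fold higher number from compound 3 to compound 4 (0.30 log units; within the scatter). Compound 4 is therefore estimated at 1800 nM, expected between 500 nM and 6500 nM.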

Compound 4, half-maximal inhibitory concentration: 780 nM
Beside the measured number, compound 4's estimate is 2.3-fold (0.36 log units) above it; measured number inside the range.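

Going from 4-fluorophenyl to 2,4-difluorophenyl in this assay gives a 1.2-fold lower number from compound 3 to compound 4 (0.07 log units; within the scatter), so this change leaves the number within the scatter on this core. Set beside the earlier step, the same kind of change does not carry over from one core to the other at one size: the same change on two cores in this assay, a 16-fold higher number (1.20 log units; beyond the scatter) from compound 2 to compound 1 and a 1.2-fold lower number (0.07 log units; within the scatter) from compound 3 to compound 4, 18-fold (1.27 log units) apart, beyond the scatter of two such steps. This does not tie the gap to the core alone, for the fluoro in compound 4 enters at another place, ortho to a large group and meta to a fluoro group, and one step per core gives no general rule.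

The compounds shown leave open how a fluoro at that same place would behave on the core of compound 2. They also leave open whether a chloro or a methoxy group entering there would follow the fluoro.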